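Bromo to chloro on the shared core

The source may hold more compounds than are shown below. What is called first, only, known or untested is meant among the compounds shown, and "the series" means these compounds.

- compound 1 `COc1cc(CCc2ccccc2)cc(OC)c1O`: 7830 nM
- compound 2 `COc1cc(CCc2ccc(Br)cc2)cc(OC)c1O`: 8490 nM

Of the compounds shown here, two have been measured so far in a functional assay on HepG2 cells (Homo sapiens) for antiproliferative activity, read by MTT assay, with a stated time of 72 h (on this read-out lower numbers stand for stronger inhibition and higher numbers for weaker inhibition), and compound 2, at 8490 nM, lies within the scatter of compound 1. The next compound, compound 3 `COc1cc(CCc2ccc(Cl)cc2)cc(OC)c1O`, differs from compound 2 as follows: chloro in place of bromo on an aromatic carbon. In words, it has chloro in place of bromo on an aromatic carbon.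

Going by the values given here, one measured step bears on this change: a 1.1-fold higher number from compound 1 to compound 2 (0.04 log units; within the scatter). It put bromo in place of hydrogen on an aromatic carbon and stayed within the scatter. With hydrogen and bromo giving values this close, no step beyond the scatter is expected in this assay when chloro replaces bromo, though a single step is thin evidence. The expected change is a 1.1-fold lower number from compound 2 to compound 3 (0.03 log units; within the scatter). Compound 3 is estimated at 8000 nM. The expected range for compound 3 runs from 4500 nM to 14000 nM.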

Compound 3, half-maximal inhibitory concentration: 8780 nM
Compound 3: middle estimate off by 1.1-fold (0.04 log units), on the low side; the measured number falls inside the stated range.
By their numbers in this assay, from the lowest: compounds 1, 2 and 3 (each within the scatter of the next).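

In this assay the change from bromo to chloro gives a 1.0-fold higher number from compound 2 to compound 3 (0.01 log units; within the scatter) and the change from hydrogen to chloro gives a 1.1-fold higher number from compound 1 to compound 3 (0.05 log units; within the scatter) and both steps lie within the scatter. On this aromatic carbon, para to a large group, chloro therefore separates from neither hydrogen nor bromo, so the flat reading now covers two halogens and not one. No evidence is available on what lies behind this result.

The compounds shown leave open whether a group of another kind at this place, such as an amine, a carboxylic acid or a longer chain, would move the number beyond the scatter. They also leave open whether a change elsewhere on the shared core, for instance at its hydroxyl group, would do so.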